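The source may hold more compounds than are shown below. What is called first, only, known or untested is meant among the compounds shown, and "the series" means these compounds.

Measured in a functional assay on A549 cells (Homo sapiens) for inhibition, read by MTT assay, with a stated time of 72 h; on this read-out lower numbers stand for stronger inhibition and higher numbers for weaker inhibition:
- compound 1 `CN(C(=O)NC(=O)c1cccc(C(F)(F)F)c1)c1nc(C(F)(F)F)c(C(=O)N/N=C/c2ccccc2C(F)(F)F)s1` gives 12.1 ug/mL
- compound 2 `CN(C(=O)NC(=O)c1ccccc1F)c1nc(C(F)(F)F)c(C(=O)N/N=C/c2ccccc2C(F)(F)F)s1` gives 6.32 ug/mL
- compound 3 `CN(C(=O)NC(=O)c1c(F)cccc1F)c1nc(C(F)(F)F)c(C(=O)N/N=C/c2ccccc2C(F)(F)F)s1` gives 17.9 ug/mL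

Compound 3 has the highest number of the three. Its gap to compound 1 is small, a 1.5-fold higher number from compound 1 to compound 3 (0.17 log units; within the scatter), whereas its gap to compound 2 is larger, a 2.8-fold higher number from compound 2 to compound 3 (0.45 log units; beyond the scatter). Compound 4 `CN(C(=O)NC(=O)c1ccc(C(F)(F)F)cc1)c1nc(C(F)(F)F)c(C(=O)N/N=C/c2ccccc2C(F)(F)F)s1` differs from compound 3 only at the aryl group on the carbonyl carbon: 4-(trifluoromethyl)phenyl in place of 2,6-difluorophenyl on a carbonyl carbon. The step that bears most directly on this change is the one exchanging a trifluoromethyl-bearing phenyl for the 2,6-difluorophenyl, a 1.5-fold higher number from compound 1 to compound 3 (0.17 log units; within the scatter), which stayed within the scatter; the other aryl exchange, a 1.9-fold lower number from compound 1 to compound 2 (0.28 log units; within the scatter), was also within the scatter. A modest move, if any, is therefore expected, a 1.5-fold lower number from compound 3 to compound 4 (0.17 log units; within the scatter). Compound 4 is estimated at 12 ug/mL, with a range from 5 ug/mL to 30 ug/mL.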

Compound 4, half-maximal inhibitory concentration: 6.68 ug/mL
The estimate for compound 4 lay 1.8-fold (0.25 log units) above the measured number, within the range that was stated.
By their numbers in this assay, from the lowest: compounds 2, 4, 1 and 3 (each within the scatter of the next, the first and the last beyond it).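

In this assay, putting 4-(trifluoromethyl)phenyl in place of 2,6-difluorophenyl on the carbonyl carbon gives a modest change beyond the scatter (a 2.7-fold lower number from compound 3 to compound 4 (0.43 log units; beyond the scatter)). The new group stands level with the 2-fluorophenyl of compound 2 (a 1.1-fold higher number from compound 2 to compound 4 (0.02 log units; within the scatter)) and with the 3-(trifluoromethyl)phenyl of compound 1 (a 1.8-fold lower number from compound 1 to compound 4 (0.26 log units; within the scatter)), so compound 3 is separated from compound 2 and compound 4 but not from compound 1. Nothing measured here accounts for these differences. Still open, as far as these compounds go, is how this carbonyl carbon would tolerate a group other than substituted phenyl, such as an amine or a cyclohexyl ring.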